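The source may hold more compounds than are shown below. What is called first, only, known or untested is meant among the compounds shown, and "the series" means these compounds.

Compound 3, `Cc1cn([C@@H]2C[C@H](O)[C@@H](CNC(=O)Nc3ccc(-c4ccc(C(F)(F)F)nc4)cc3)O2)c(=O)[nH]c1=O`, is the reference for this step. In an ADME assay on MRC5 cells (Homo sapiens) for cytotoxicity (a higher number here means that more compound is tolerated, a lower number that less compound is tolerated), compound 3 gives > 50000 nM, which is a limit of the assay and not a number. Compound 1, `COc1ccc(NC(=O)NC[C@H]2O[C@H](n3cc(C)c(=O)[nH]c3=O)C[C@@H]2O)cc1`, gives > 50000 nM in this assay, again a limit. Compound 2, `Cc1cn([C@@H]2C[C@H](O)[C@@H](CNC(=O)Nc3ccc(C(C)(C)C)cc3)O2)c(=O)[nH]c1=O`, gives > 50000 nM in this assay, also a limit. The steps among these three compounds cannot be sized: a step that the two limits leave unreadable from compound 1 to compound 2, a step that the two limits leave unreadable from compound 1 to compound 3 and a step that the two limits leave unreadable from compound 2 to compound 3 all stay unreadable because of the limit of > 50000 nM in this assay, at which 3 of the 3 values shown sit. Compound 4 is `Cc1cn([C@@H]2C[C@H](O)[C@@H](CNC(=O)Nc3ccc(OCc4cccc(Cl)c4)cc3)O2)c(=O)[nH]c1=O`; it differs from compound 3 in one place: (3-chlorobenzyl)oxy in place of 6-(trifluoromethyl)pyridin-3-yl on an aromatic carbon. Within the data shown here, no measured step bears directly on this change, and the three other groups tried on the same aromatic carbon all left the read-out in this assay at the limit. Compound 4 is therefore expected to sit at the limit as well. The expected step is a step that the limit leaves unreadable from compound 3 to compound 4, meaning nothing readable. The estimate for compound 4 in this assay is 60000 nM, with a range from 30000 nM to 150000 nM, and a strong chance that only a limit is reported.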

Compound 4, half-maximal cytotoxic concentration: > 50000 nM
Compound 4: no number, only a limit; the forecaster's own chance of this, stated with the estimate: 80%; the middle value lies beyond the limit too.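

Steps from compound 1, compound 2 and compound 3 to compound 4 cannot be read in this assay, because every value is a limit and not a number: the limit of > 50000 nM in this assay, at which 4 of the 4 values shown sit.

The compounds shown leave open whether any group on this aromatic carbon reduces the concentration tolerated in this assay.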